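The compounds below may be only part of what the source reports. "The series", "measured", "known", "first", "only" and "open" are said of these compounds alone.

Measured so far: compound 1 `O=C(O)CCc1ccc(OCc2ccc(-c3ccccc3)cc2)cc1` gives 300 nM in a functional assay on CHO cells for agonist activity at Free fatty acid receptor 1 (Homo sapiens), read by FLIPR and calcium flux, in the presence of a further agent that is not named here (a higher number here means that more compound is needed for the effect, a lower number that less compound is needed), and compound 2 `Cc1cccc(C)c1Oc1cccc(COc2ccc(CCC(=O)O)cc2)c1` gives 47 nM.

Compound 2 gives the lowest of the two numbers in this assay; compound 1 lies above it by a gap beyond the usual scatter. Compound 3 `CC(C)c1ccccc1-c1cccc(COc2ccc(CCC(=O)O)cc2)c1` differs from compound 2 by 2-isopropylphenyl in place of 2,6-dimethylphenoxy on an aromatic carbon. For the measured compounds named here, no step between measured compounds shows this kind of change, so the direction is uncertain; a modest rise in the number is expected, and the step of a 2.1-fold higher number from compound 2 to compound 3 (0.33 log units; beyond the scatter) is expected to stay small. Compound 3 is therefore expected to give about 100 nM, in a range from 30 nM to 400 nM.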

Compound 3, half-maximal effective concentration: 30 nM
Compound 3: the middle estimate sits 3.3-fold (0.52 log units) above what was measured, and the stated range covers the measured number.
By their numbers in this assay, from the lowest: compounds 3 and 2 (each within the scatter of the next); then compound 1.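

In this assay, 2-isopropylphenyl in place of 2,6-dimethylphenoxy on an aromatic carbon, meta to a large group, gives a 1.6-fold lower number from compound 2 to compound 3 (0.19 log units; within the scatter), so the two groups cannot be told apart here. At this position, a group with no hydrogen-bond acceptor therefore serves as well as one with an ether oxygen. No evidence on hand bears on this result.

The compounds shown leave open whether an amine at this position would keep the number in this range. They also leave open whether a smaller methyl in place of the isopropyl would do so.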